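The compounds below may be only part of what the source reports. "The series", "measured", "known", "first", "only" and "open" are said of these compounds alone.

Working notes on the series in a functional assay on HepG2 cells (Homo sapiens) for antiproliferative activity, read by MTT assay; a lower number here means a stronger inhibitor, a higher number a weaker inhibitor: compound 1 `Cc1c(-n2cc(COc3ccc(/C=C/C(=O)c4cc5c(cc4O)OC(C)(C)CC5)cc3)nn2)cccc1[N+](=O)[O-]` gives 109000 nM, compound 2 `CCc1ccccc1-n1cc(COc2ccc(/C=C/C(=O)c3cc4c(cc3O)OC(C)(C)CC4)cc2)nn1` gives 115000 nM and compound 3 `Cc1ccc(-n2cc(COc3ccc(/C=C/C(=O)c4cc5c(cc4O)OC(C)(C)CC5)cc3)nn2)cc1Br` gives 117000 nM. Compound 3 therefore stands level with the other two. The measured steps are a 1.1-fold higher number from compound 1 to compound 2 (0.02 log units; within the scatter), a 1.1-fold higher number from compound 1 to compound 3 (0.03 log units; within the scatter) and a 1.0-fold higher number from compound 2 to compound 3 (0.01 log units; within the scatter).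

Compound 4 `CCCCCn1cc(COc2ccc(/C=C/C(=O)c3cc4c(cc3O)OC(C)(C)CC4)cc2)nn1` has pentyl in place of 3-bromo-4-methylphenyl on an aromatic nitrogen. All three measured steps exchange one substituted phenyl for another, and none puts an open chain at this place, so they are only a weak guide. No shift beyond the scatter is expected in this assay, in either direction. The expected step is a 1.2-fold lower number from compound 3 to compound 4 (0.07 log units; within the scatter). The estimate for compound 4 is 100000 nM, with an expected range of 45000 nM to 190000 nM.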

Compound 4, half-maximal inhibitory concentration: 95800 nM
Compound 4: the middle estimate sits 1.0-fold (0.02 log units) above what was measured, and the stated range covers the measured number.
By their numbers in this assay, from the lowest: compounds 4, 1, 2 and 3 (each within the scatter of the next).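

Pentyl on the aromatic nitrogen reads level with all three substituted phenyl groups in this assay (a 1.2-fold lower number from compound 3 to compound 4 (0.09 log units; within the scatter); a 1.2-fold lower number from compound 2 to compound 4 (0.08 log units; within the scatter); a 1.1-fold lower number from compound 1 to compound 4 (0.06 log units; within the scatter)). The earlier steps exchanged only one substituted phenyl for another, whereas this open chain has no ring, so among the compounds shown, a six-membered aromatic ring at this place is not needed for a number at this level.

Going by these compounds, it remains open whether an amine or a carboxylic acid at the end of the pentyl chain would give a step beyond the scatter. The same question stands for a longer chain such as decyl. No supporting measurement bears on why these numbers stand level.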